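The source may hold more compounds than are shown below. What is called first, only, known or untested is meant among the compounds shown, and "the series" means these compounds.

Three esters built on one shared core have been tested in a functional assay on the whole organism with Scenedesmus acutus as the target; a lower number here means a stronger inhibitor, a higher number a weaker inhibitor. In this test, compound 1 `CCOC(=O)c1cc(N2C(=O)C3=C(CCCC3)C2=O)c(F)cc1Cl` gives 100 nM, compound 2 `CCCOC(=O)c1cc(N2C(=O)C3=C(CCCC3)C2=O)c(F)cc1Cl` gives 89.1 nM and compound 3 `CC(C)OC(=O)c1cc(N2C(=O)C3=C(CCCC3)C2=O)c(F)cc1Cl` gives 57.5 nM. Compound 3 therefore cannot be separated from the other two, as the steps show: a 1.7-fold lower number from compound 1 to compound 3 (0.24 log units; within the scatter) and a 1.5-fold lower number from compound 2 to compound 3 (0.19 log units; within the scatter).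

Compound 4 `CCC(C)OC(=O)c1cc(N2C(=O)C3=C(CCCC3)C2=O)c(F)cc1Cl` differs from compound 3 by one small change: methyl in place of hydrogen on a saturated chain carbon, two bonds along the chain from an oxygen next to a carbonyl group. A methyl takes the place of a hydrogen on a saturated chain carbon, two bonds along the chain from an oxygen next to a carbonyl group, so isopropyl becomes sec-butyl.

The closest guide is the same change made on a different chain, a 1.1-fold lower number from compound 1 to compound 2 (0.05 log units; within the scatter). The other methyl addition sits on a different carbon and also stays small, a 1.7-fold lower number from compound 1 to compound 3 (0.24 log units; within the scatter). No step beyond the scatter is therefore expected, and the expected step is a 1.0-fold lower number from compound 3 to compound 4 (0.02 log units; within the scatter). For compound 4 the estimated value is 55 nM, with an expected range of 28 nM to 110 nM.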

Compound 4, half-maximal inhibitory concentration: 24.6 nM
Compound 4: the middle estimate sits 2.2-fold (0.35 log units) above what was measured, and the stated range ends above it.
By their numbers in this assay, from the lowest: compound 4; then compounds 3, 2 and 1 (each within the scatter of the next).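

Among these four esters, sec-butyl is the first group to separate clearly from the others in this assay (a 2.3-fold lower number from compound 3 to compound 4 (0.37 log units; beyond the scatter)) (a 3.6-fold lower number from compound 2 to compound 4 (0.56 log units; beyond the scatter)) (a 4.1-fold lower number from compound 1 to compound 4 (0.61 log units; beyond the scatter)), which makes compound 4 the strongest inhibitor here, though each step is modest. Adding a methyl two bonds along the chain from the oxygen gives one step within the scatter and one beyond it, yet these steps cannot be told apart: the same change on two cores in this assay, a 1.1-fold lower number (0.05 log units; within the scatter) from compound 1 to compound 2 and a 2.3-fold lower number (0.37 log units; beyond the scatter) from compound 3 to compound 4, 2.1-fold (0.32 log units) apart, within the scatter of two such steps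
Adding a methyl on the saturated chain carbon bound to that oxygen also gives one step on each side of the scatter, and the same caution applies: the same change on two cores in this assay, a 1.7-fold lower number (0.24 log units; within the scatter) from compound 1 to compound 3 and a 3.6-fold lower number (0.56 log units; beyond the scatter) from compound 2 to compound 4, 2.1-fold (0.32 log units) apart, within the scatter of two such steps

On these data alone, whether the trend continues with a longer chain or a cyclopentyl ester remains open, as does the effect of replacing the ester with a carboxylic acid. All four compounds share one core, so it is also unknown whether sec-butyl would stand out on another core.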